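Trifluoromethyl for Phenyl in a Salicylanilide Series

The source may hold more compounds than are shown below. What is called first, only, known or untested is meant among the compounds shown, and "the series" means these compounds.

Among the compounds with values here, compound 1 `N#Cc1ccc(NC(=O)c2cc(-c3ccccc3)ccc2O)cc1` is the only compound here with a measured number: in a functional assay on HL-60 cells (Homo sapiens) for cytotoxicity, read by luminescence and CellTiter-Glo, with a stated time of 3 days (a lower number here means a stronger inhibitor, a higher number a weaker inhibitor), compound 1 gives 1350 nM. Compound 2 `O=C(Nc1ccccc1)c1cc(F)ccc1O` gives in this assay > 10000 nM, which is a limit of the assay rather than a number, in keeping with the limit of > 10000 nM in this assay, at which 1 of the 2 values shown sits. Compound 3 `N#Cc1ccc(NC(=O)c2cc(C(F)(F)F)ccc2O)cc1` differs from compound 1 by trifluoromethyl in place of phenyl on an aromatic carbon. Within the data shown here, no measured step guides this change, so compound 3 is expected to be somewhat weaker than compound 1, the step from compound 1 to compound 3 a 3.0-fold higher number from compound 1 to compound 3 (0.47 log units; beyond the scatter) estimated beyond the scatter. Compound 3 is expected to give 4000 nM, within 1400 nM to 12000 nM.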

Compound 3, half-maximal inhibitory concentration: 3120 nM
Beside the measured number, compound 3's estimate is 1.3-fold (0.11 log units) above it; the measured number falls inside the stated range.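

In this assay, trifluoromethyl in place of phenyl on this aromatic carbon, para to a hydroxy group, gives a 2.3-fold higher number from compound 1 to compound 3 (0.36 log units; beyond the scatter), a modest step. Compound 3 still gives a measured number, so a ring at this position is not required for a measurable result in this pair, although phenyl gives the stronger compound. Nothing shown here accounts for the size of this step. From the compounds shown here alone, it remains open how an amine, a carboxylic acid or a methoxy group at this position would compare with phenyl and trifluoromethyl. Going by these compounds, whether the step would hold without the nitrile also remains open.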